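The source may hold more compounds than are shown below. What is called first, only, known or untested is meant among the compounds shown, and "the series" means these compounds.

In an ADME assay on cells (Hepatocyte, Mus musculus) for metabolic stability, with a stated time of 30 min (on this read-out higher numbers stand for a more stable compound and lower numbers for a less stable compound), compound 3 `CC(=O)OC1CCC(CN2CCN(c3cc(=O)c4cc(C(F)(F)F)cc([N+](=O)[O-])c4s3)CC2)CC1` gives 0% and stands lowest of the three measured compounds. Compound 1 `O=C(OC1CCC(CN2CCN(c3cc(=O)c4cc(C(F)(F)F)cc([N+](=O)[O-])c4s3)CC2)CC1)c1ccccc1` gives 68.1% and compound 2 `O=C(NC1CCC(CN2CCN(c3cc(=O)c4cc(C(F)(F)F)cc([N+](=O)[O-])c4s3)CC2)CC1)c1ccccc1` gives 90.6% on the same read-out. Compound 4 `O=C(OC1CCC(CN2CCN(c3cc(=O)c4cc(C(F)(F)F)cc([N+](=O)[O-])c4s3)CC2)CC1)c1ccco1` differs from compound 3 by furan-2-yl in place of methyl on a carbonyl carbon with furan-2-yl in place of methyl on a carbonyl carbon. The closest measured change, methyl in place of phenyl on a carbonyl carbon, is large and shows a number 68.1 percentage points lower from compound 1 to compound 3 (beyond the scatter) in the opposite direction to the one at issue. Less direct is a number 90.6 percentage points lower from compound 2 to compound 3 (beyond the scatter) with acetoxy in place of benzamido on a saturated ring carbon. Within the data shown here, the expected change is a number 55 percentage points higher from compound 3 to compound 4 (beyond the scatter) as a large rise, although no measured compound carries furan-2-yl. Compound 4 is expected at 55% within a range of 25% to 80% on this estimate.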

Compound 4, percent of the compound remaining: 0.6%
For compound 4 the middle estimate is 54.4 percentage points above the measured one, outside the stated range (below it).
By their numbers in this assay, from the lowest: compounds 3 and 4 (each within the scatter of the next); then compound 1; then compound 2.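

In this assay, furan-2-yl in place of methyl on the carbonyl carbon gives a number 0.6 percentage points higher from compound 3 to compound 4 (within the scatter), so a five-membered aromatic ring at this place does not bring back the value seen with phenyl. Furan-2-yl in place of phenyl gives a number 67.5 percentage points lower from compound 1 to compound 4 (beyond the scatter), and ((furan-2-yl)carbonyl)oxy in place of benzamido gives a number 90 percentage points lower from compound 2 to compound 4 (beyond the scatter), so among these esters only the phenyl compound keeps a substantial number. Nothing available explains why the two rings differ. On these data alone, it remains open whether thiophen-2-yl or pyridyl on the carbonyl carbon would stand with phenyl or with furan-2-yl, and whether furan-2-yl joined through an amide would follow compound 2.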